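Aryl replacement on the shared core: outlook for compound 4

This account rests on a few compounds, and the source may have more. Where it says the series, first, only, none or still open, it means among the compounds named here.

Measured compounds in a functional assay on HT-29 cells (Homo sapiens) for antiproliferative activity, read by sulforhodamine B assay, with a stated time of 48 h; a lower number here means a stronger inhibitor of growth, a higher number a weaker inhibitor of growth:
- compound 1 `NS(=O)(=O)NCC1CCN(c2cc(-c3ccccc3)ncn2)CC1`: > 100000 nM
- compound 2 `COc1ccc(-c2cc(N3CCC(CNS(N)(=O)=O)CC3)ncn2)cc1`: > 100000 nM
- compound 3 `COC(=O)c1ccc(-c2cc(N3CCC(CNS(N)(=O)=O)CC3)ncn2)cc1`: 22900 nM

The values for compound 1 and compound 2 are limits of this assay, not numbers; compound 3 gives a measured number. Compound 2 therefore stands at the limit of > 100000 nM in this assay, at which 2 of the 3 values shown sit, and its position within that limit is not resolved.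

Compound 4 `NS(=O)(=O)NCC1CCN(c2cc(-c3ccccc3Cl)ncn2)CC1` differs from compound 2 in one place: 2-chlorophenyl in place of 4-methoxyphenyl on an aromatic carbon.

The steps measured so far touch the same aromatic carbon. From compound 1 to compound 2 the two limits leave the step unreadable: a step that the two limits leave unreadable from compound 1 to compound 2. Methoxycarbonyl gives a readable step, an at least 4.3-fold lower number from compound 1 to compound 3 (0.64 log units; beyond the scatter) and an at least 4.3-fold lower number from compound 2 to compound 3 (0.64 log units; beyond the scatter), but neither involves 2-chlorophenyl, and no measured compound carries it. There is no basis to expect a step of the size seen with methoxycarbonyl.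

Compound 4 is expected to remain near the limit, at 90000 nM with a range of 20000 nM to 400000 nM, the expected step being an at least 1.1-fold lower number from compound 2 to compound 4 (0.04 log units; that floor lies within the scatter).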

Compound 4, concentration for 50% growth inhibition: > 100000 nM
Compound 4: no number, only a limit; the forecaster's own chance of this, stated with the estimate: 60%; middle value at least 1.1-fold (0.04 log units) from the limit.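

No new step can be read between compound 4 and compound 1 or compound 2, since all three give only a limit, not a number: the limit of > 100000 nM in this assay, at which 3 of the 4 values shown sit.

The compounds shown leave open how far each of the three lies beyond that limit, and whether 2-chlorophenyl and 4-methoxyphenyl differ at all.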